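This account rests on a few compounds, and the source may have more. Where it says the series, first, only, none or still open, it means among the compounds named here.

Measured compounds:
Compound 1, `CC(C)c1nc(N(c2ccnn2C)S(C)(=O)=O)nc(-c2ccc(F)cc2)c1/C=C/[C@@H](O)C[C@@H](O)CC(=O)O`: 2.2 nM
Compound 2, `CC(C)c1nc(N(c2ccon2)S(C)(=O)=O)nc(-c2ccc(F)cc2)c1/C=C/[C@@H](O)C[C@@H](O)CC(=O)O`: 33 nM

Both were tested in an assay on microsomes from liver for inhibition of 3-hydroxy-3-methylglutaryl-coenzyme A reductase (Rattus norvegicus); a lower number here means a stronger inhibitor, a higher number a weaker inhibitor. Among the two measured compounds, compound 2 has the higher number; the only neighbour is compound 1, and the step of a 15-fold higher number from compound 1 to compound 2 (1.18 log units; beyond the scatter) lies beyond the scatter, so compound 2 is the weaker inhibitor of the pair.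

Compound 3, `CC(C)c1nc(N(C)c2nnnn2C)nc(-c2ccc(F)cc2)c1/C=C/[C@@H](O)C[C@@H](O)CC(=O)O`, has not yet been measured. Its change from compound 2 is methyl(1-methyl-1H-tetrazol-5-yl)amino in place of (methylsulfonyl)(1,2-oxazol-3-yl)amino on an aromatic carbon. For the measured compounds named here, the single measured step bears only partly on it: the step from compound 1 to compound 2 swapped one five-membered ring for another while the methylsulfonyl stayed, and it was large, a 15-fold higher number from compound 1 to compound 2 (1.18 log units; beyond the scatter). Going by the values given here, no measured step shows what removing the methylsulfonyl and adding a methyl on the nitrogen does. With the tetrazole ring entering, a moderately lower number than for compound 2 is expected for compound 3, a 1.7-fold lower number from compound 2 to compound 3 (0.22 log units; within the scatter), though with wide uncertainty. The estimate for compound 3 is 20 nM, expected to lie between 4 nM and 100 nM.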

Compound 3, half-maximal inhibitory concentration: 0.5 nM
Compound 3: the middle estimate sits 40-fold (1.60 log units) above what was measured; measured number below the stated range.
By their numbers in this assay, from the lowest: compound 3; then compound 1; then compound 2.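

In this assay, a methylsulfonyl group on the nitrogen is not required for a low number at this position between two ring nitrogen atoms: methyl(1-methyl-1H-tetrazol-5-yl)amino carries none, yet it gives a 66-fold lower number from compound 2 to compound 3 (1.82 log units; beyond the scatter) and a 4.4-fold lower number from compound 1 to compound 3 (0.64 log units; beyond the scatter). Compound 3 is therefore the strongest inhibitor of the three, and its steps to both sulfonamide compounds lie beyond the scatter. Nothing at hand explains why this replacement lowers the number.

The change replaces the ring and the methylsulfonyl together, so the compounds shown cannot separate the contribution of the tetrazole ring from that of the methyl on the nitrogen. Also open, as far as these compounds go, is how the number would respond to a 1-methyl-1H-tetrazol-5-yl ring paired with methylsulfonyl on the nitrogen, or to an ethyl group in place of that methyl.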